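The compounds below may be only part of what the source reports. "The series", "measured", "known", "first", "only" and "open" are said of these compounds alone.

Measured compounds:
compound 1 `CC(C)Nc1sc(C(=O)c2ccc(Cl)s2)c(N)c1C#N` — 192 nM
compound 2 `CCNc1sc(C(=O)c2ccc(Cl)s2)c(N)c1C#N` — 222 nM
compound 3 `C=CCNc1sc(C(=O)c2ccc(Cl)s2)c(N)c1C#N` — 638 nM

Values are half-maximal inhibitory concentrations in an assay for inhibition of Maternal embryonic leucine zipper kinase (Homo sapiens), read by ADP-Glo, with a stated time of 0.5 h; on this read-out higher numbers stand for weaker inhibition and lower numbers for stronger inhibition. Compound 3 stands at the highest of the three numbers; its nearest neighbour is compound 2, via a 2.9-fold higher number from compound 2 to compound 3 (0.46 log units; beyond the scatter), and the wider gap is a 3.3-fold higher number from compound 1 to compound 3 (0.52 log units; beyond the scatter). Compound 1 and compound 2 differ by a 1.2-fold higher number from compound 1 to compound 2 (0.06 log units; within the scatter).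

Compound 4 `N#Cc1c(NCc2ccccc2)sc(C(=O)c2ccc(Cl)s2)c1N` is not yet measured. The change from compound 3 is phenyl in place of vinyl on a saturated chain carbon bound to a nitrogen on an aromatic ring. Among the compounds with values here, no measured step covers a phenyl at this place; the steps that bear on it are those into compound 3, which lowered potency by a modest amount when allyl replaced isopropyl or ethyl. A further change at the same position of unknown effect is expected to stay near compound 3, with wide uncertainty: compound 4 is estimated at 650 nM (range 220 nM to 1900 nM), a step of a 1.0-fold higher number from compound 3 to compound 4 (0.01 log units; within the scatter) that is expected to be within the scatter.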

Compound 4, half-maximal inhibitory concentration: > 5000 nM
Compound 4: a limit, no number; the forecaster's own chance of this, stated with the estimate: 5%; middle value at least 7.6-fold (0.88 log units) away from the limit.
By their numbers in this assay, from the lowest: compounds 1 and 2 (each within the scatter of the next); then compound 3. At a limit, above all of these: compound 4.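

Compound 4 stands at a limit of this assay, not at a number: the limit of > 5000 nM in this assay, at which 1 of the 4 values shown sits. With benzyl on the nitrogen, the steps read an at least 7.8-fold higher number from compound 3 to compound 4 (0.89 log units; beyond the scatter), an at least 22-fold higher number from compound 2 to compound 4 (1.35 log units; beyond the scatter) and an at least 26-fold higher number from compound 1 to compound 4 (1.41 log units; beyond the scatter). Among the earlier compounds this place showed modest steps at most, whereas the phenyl shows that it can cost far more.

How far compound 4 lies past the limit cannot be read. Open too, from the compounds shown here alone, is whether cyclohexylmethyl or a longer chain such as n-butyl on this nitrogen would follow compound 4 or compounds 1 and 2.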